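The compounds below may be only part of what the source reports. "The series", "measured", "known", "first", "only" and "open" are said of these compounds alone.

Measured compounds:
- compound 1 `CC1(C)[C@H]2CC[C@]1(C)N(Cc1cn(-c3ccc(Cl)cc3)nn1)C(=O)C2`, in a functional assay on SGC-7901 cells (Homo sapiens) for inhibition, read by MTT assay, with a stated time of 24 h (on this read-out higher numbers stand for weaker inhibition and lower numbers for stronger inhibition), giving 410 nM
- compound 2 `COc1ccc(-n2cc(CN3C(=O)C[C@@H]4CC[C@@]3(C)C4(C)C)nn2)cc1`, giving in this assay 480 nM
- compound 3 `CC1(C)[C@H]2CC[C@]1(C)N(Cc1cn(-c3ccccc3C#N)nn1)C(=O)C2`, giving in this assay 260 nM

Compound 1 gives the second highest of these three numbers, but all three sit close together: from compound 1 to compound 2 the change is a 1.2-fold higher number from compound 1 to compound 2 (0.07 log units; within the scatter), and from compound 1 to compound 3 it is a 1.6-fold lower number from compound 1 to compound 3 (0.20 log units; within the scatter), so none of the three can be told apart on these data.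

Compound 4 `COc1cccc(-n2cc(CN3C(=O)C[C@@H]4CC[C@@]3(C)C4(C)C)nn2)c1` has not yet been measured. It differs from compound 1 in one place: 3-methoxyphenyl in place of 4-chlorophenyl on an aromatic nitrogen. Going by the values given here, two measured steps bear on this. The step from compound 1 to compound 2, a methoxy in place of chloro on an aromatic carbon, was a 1.2-fold higher number from compound 1 to compound 2 (0.07 log units; within the scatter). The step from compound 1 to compound 3, which also replaces the 4-chlorophenyl on the aromatic nitrogen, was a 1.6-fold lower number from compound 1 to compound 3 (0.20 log units; within the scatter). Both lie within the scatter, so for the move to a 3-methoxyphenyl no step beyond the scatter is expected either, in either direction. The expected step from compound 1 to compound 4 in this assay is therefore a 1.1-fold higher number from compound 1 to compound 4 (0.04 log units; within the scatter). Compound 4 is estimated at 450 nM, most likely between 200 nM and 1000 nM.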

Compound 4, half-maximal inhibitory concentration: 590 nM
Compound 4: the middle estimate sits 1.3-fold (0.12 log units) below what was measured, within the range that was stated.
By their numbers in this assay, from the lowest: compounds 3, 1, 2 and 4 (each within the scatter of the next, the first and the last beyond it).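

In this assay the 3-methoxyphenyl group can stand on the aromatic nitrogen with little visible effect: replacing 4-methoxyphenyl gives a 1.2-fold higher number from compound 2 to compound 4 (0.09 log units; within the scatter) and replacing 4-chlorophenyl gives a 1.4-fold higher number from compound 1 to compound 4 (0.16 log units; within the scatter) in the same read-out. Going by these compounds alone, the new information is a 2.3-fold higher number from compound 3 to compound 4 (0.36 log units; beyond the scatter) on replacing 2-cyanophenyl, the first step at this position to pass beyond the scatter, though only modestly. Compound 3 remains within the scatter of compound 1 and compound 2, so this step separates only the two ends of the set and does not single out one group as better than all the others.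

Nothing shown here gives a reason for that gap. On these data alone, it also remains open whether a phenyl ring carrying an amine or a carboxylic acid, or a longer chain in its place, would move the number further than these groups do.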